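Acetyl to Propanoyl on a Second Core

This account rests on a few compounds, and the source may have more. Where it says the series, first, only, none or still open, it means among the compounds named here.

Measured compounds:
Compound 1, `CCC(=O)N1CCN(S(=O)(=O)c2ccc(F)cc2)CC1`: 0.01 mg/kg
Compound 2, `CC(=O)N1CCN(S(=O)(=O)c2ccc(F)cc2)CC1`: 0.01 mg/kg
Compound 3, `CC(=O)N1CCCN(S(=O)(=O)c2ccc(F)cc2)CC1`: 1 mg/kg

In a functional assay on the whole organism with Mus musculus as the target (a higher number here means that more compound is needed for the effect, a lower number that less compound is needed), compound 2 gives 0.01 mg/kg and compound 1 gives 0.01 mg/kg. The two share one core and differ by methyl in place of hydrogen on a saturated chain carbon bound to a carbonyl carbon; the step of no change at the digits printed from compound 2 to compound 1 (within the scatter) shows that this change left the read-out where it was. Compound 3 stands on a different core: it differs from compound 2 in more than one place, and the difference between the two cores is not broken down here. In this assay compound 3 gives 1 mg/kg, a number far above those of compound 1 and compound 2.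

Compound 4, `CCC(=O)N1CCCN(S(=O)(=O)c2ccc(F)cc2)CC1`, has not yet been measured. It differs from compound 3 by methyl in place of hydrogen on a saturated chain carbon bound to a carbonyl carbon, the same change that carried compound 2 to compound 1. Because that earlier step no change at the digits printed from compound 2 to compound 1 (within the scatter) stayed within the scatter, the step of no change at the digits printed from compound 3 to compound 4 (within the scatter) is expected to be small as well. On that basis compound 4 is estimated to give 1 mg/kg in this assay, with a likely range from 0.3 mg/kg to 3 mg/kg; this rests on a single precedent, so the range is kept wide.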

Compound 4, minimum effective dose: 1 mg/kg
Estimate against measurement, compound 4: no gap at the digits printed; the measured number falls inside the stated range.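

In this assay, putting methyl in place of hydrogen on a saturated chain carbon bound to a carbonyl carbon gives no change at the digits printed from compound 3 to compound 4 (within the scatter), so the acetyl to propanoyl swap reads the same on this core as on the first. Set side by side, the two steps agree: the same change on two cores in this assay, no change at the digits printed (within the scatter) from compound 2 to compound 1 and no change at the digits printed (within the scatter) from compound 3 to compound 4, 1.0-fold (0.00 log units) apart, within the scatter of two such steps

Going by these compounds alone, this shows that, for these two pairs, the effect of the change carried over from one core to the other, and that a flat result on one core correctly pointed to a flat result on the other, but it rests on only two cores and says nothing about a third core or about why both steps are flat.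

As far as these compounds go, it remains open whether a longer chain than propanoyl, or an amine or a carboxylic acid at the same place, would read the same way on either core. The compounds shown also leave open which part of the difference between the two cores matters for the read-out, since that difference is not broken down into single steps.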